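Benzyl-to-4-propylphenyl swap across two isomeric cores

The source may hold more compounds than are shown below. What is called first, only, known or untested is meant among the compounds shown, and "the series" means these compounds.

Three compounds of the series have numbers in a functional assay on MGC-803 cells (Homo sapiens) for inhibition, read by sulforhodamine B assay; on this read-out lower numbers stand for stronger inhibition and higher numbers for weaker inhibition. Compound 1 `CCCc1ccc(NC2=CC(=O)c3nc4n(c3C2=O)[C@H]2OC[C@@H](O)[C@H]2OC4)cc1` gives 1560 nM in this assay. Compound 2 `O=C1C=C(NCc2ccccc2)C(=O)c2c1nc1n2[C@H]2OC[C@@H](O)[C@H]2OC1` gives 2670 nM in this assay. Compound 3 `O=C1C(NCc2ccccc2)=CC(=O)c2c1nc1n2[C@H]2OC[C@@H](O)[C@H]2OC1` gives 3490 nM in this assay. Compound 4 `CCCc1ccc(NC2=CC(=O)c3c(nc4n3[C@H]3OC[C@@H](O)[C@H]3OC4)C2=O)cc1` has not yet been measured in this assay.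

Compound 2 and compound 3 hold the same atoms joined differently; the difference between the two cores is not broken down here. Their numbers in this assay lie within the scatter of each other, so no order is drawn between them.

Within the data shown here, the one counted change is 4-propylphenyl in place of benzyl on an amine nitrogen. In this assay it gave a 1.7-fold lower number from compound 2 to compound 1 (0.23 log units; within the scatter). The same change is made on the core of compound 3: 4-propylphenyl in place of benzyl on an amine nitrogen. The place is described in the same words in both cases, so this is the same change on a differently joined core.

Among the measured compounds shown here, from compound 3 to compound 4 a step of about a 1.6-fold lower number from compound 3 to compound 4 (0.20 log units; within the scatter) in this assay is expected, resting on the single earlier instance a 1.7-fold lower number from compound 2 to compound 1 (0.23 log units; within the scatter) and on the fact that the two cores sit within the scatter of each other in this assay. For the measured compounds named here, only one prior example carries this expectation, so it is held loosely.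

Compound 4 is therefore estimated at 2200 nM in this assay, with the likely range running from 1200 nM to 4000 nM.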

Compound 4, half-maximal inhibitory concentration: 1920 nM
Compound 4: middle estimate off by 1.1-fold (0.06 log units), on the high side; the measured number falls inside the stated range.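

In this assay, 4-propylphenyl in place of benzyl on an amine nitrogen gives a 1.8-fold lower number from compound 3 to compound 4 (0.26 log units; within the scatter), and the step on this core does not differ from the one on the isomeric core: the same change on two cores in this assay, a 1.7-fold lower number (0.23 log units; within the scatter) from compound 2 to compound 1 and a 1.8-fold lower number (0.26 log units; within the scatter) from compound 3 to compound 4, 1.1-fold (0.03 log units) apart, within the scatter of two such steps

So, within this pair of cores, the way the atoms of the core are joined leaves no readable mark on the size of the step, and the change can be treated as carrying from one core to the other. This does not show that the change itself moves the number, since each of the two steps lies within the scatter on its own, and agreement between two steps this small would look the same if the true step were close to nothing. Nor does it say whether a change with a step beyond the scatter would carry over as well, as the series shows only this one swap on only these two cores.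

The amine nitrogen carries only benzyl and 4-propylphenyl in the compounds shown, so it stays open how a plain phenyl, a longer chain such as 4-butylphenyl or a carboxylic acid on the aromatic ring would read on either core. A plain phenyl would also separate the effect of the propyl chain from that of replacing benzyl with a ring bonded directly to the nitrogen.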